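The source may hold more compounds than are shown below. What is called first, only, known or untested is meant among the compounds shown, and "the series" means these compounds.

Measured so far in a functional assay on K562 cells (Homo sapiens) for inhibition, read by fluorescence, with a stated time of 72 h; on this read-out lower numbers stand for stronger inhibition of growth and higher numbers for weaker inhibition of growth:
compound 1 `CCCCCc1cc2nn(-c3ccccc3)cc2c(C)n1` gives 6900 nM;
compound 2 `Cc1nc(-c2ccccc2)cc2nn(-c3ccccc3)cc12` gives 6300 nM;
compound 3 `c1ccc(-n2cc3cnc(C4CC4)cc3n2)cc1` gives 60500 nM.

Compound 3 gives the highest number of the three, and its distance from both compound 1 and compound 2 lies beyond the scatter. The step of a 1.1-fold lower number from compound 1 to compound 2 (0.04 log units; within the scatter) shows that swapping the group on the shared core leaves the number essentially where it was.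

Compound 4 `Cc1nc(C2CC2)cc2nn(-c3ccccc3)cc12` differs from compound 3 by methyl in place of hydrogen on an aromatic carbon. Within the data shown here, no measured pair shows this methyl alone, though compound 1 and compound 2 both carry it and both give lower numbers than compound 3. The step of a 3.0-fold lower number from compound 3 to compound 4 (0.48 log units; beyond the scatter) is therefore expected to be downward, toward those two. For compound 4 the estimate in this assay is 20000 nM, within 6000 nM to 60000 nM.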

Compound 4, concentration for 50% growth inhibition: 25900 nM
Estimate against measurement, compound 4: 1.3-fold (0.11 log units) below, within the range that was stated.
By their numbers in this assay, from the lowest: compounds 2 and 1 (each within the scatter of the next); then compound 4; then compound 3.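

In this assay, a methyl next to the ring nitrogen, taken on its own, gives a 2.3-fold lower number from compound 3 to compound 4 (0.37 log units; beyond the scatter), a modest gain from a single added carbon. With that methyl kept, the other group on the ring still counts: cyclopropyl in place of phenyl gives a 4.1-fold higher number from compound 2 to compound 4 (0.61 log units; beyond the scatter), and cyclopropyl in place of pentyl gives a 3.8-fold higher number from compound 1 to compound 4 (0.57 log units; beyond the scatter). Nothing measured here explains either shift. Going by these compounds, whether an ethyl or an amine in place of the methyl would lower the number further stays open.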